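The source may hold more compounds than are shown below. What is called first, only, known or untested is meant among the compounds shown, and "the series" means these compounds.

Three compounds of this series have a number in an assay on HEK293 cells for inhibition of acid ceramidase (Homo sapiens), read by fluorescence, with stated times of 10 min and 3 h; on this read-out lower numbers stand for stronger inhibition and higher numbers for weaker inhibition. Compound 1 `CC(C)CN1CCC(c2ccc3c(c2)oc(=O)n3C(=O)NCCCCc2ccccc2)CC1` gives 120 nM and stands second highest of the three; compound 3 `CCOCCNC(=O)n1c(=O)oc2cc(-c3ccc(F)cc3)ccc21` sits nearest with 2300 nM, a gap beyond the usual scatter, while compound 2 `O=C(NCCCCc1ccccc1)n1c(=O)oc2ccncc21` lies furthest with 6 nM, also beyond the scatter. Compound 4 `CN1CCC(c2ccc3c(c2)oc(=O)n3C(=O)NCCCCc2ccccc2)CC1` differs from compound 1 only by the change (hydrogen in place of isopropyl on a saturated chain carbon bound to an amine nitrogen in a ring). For the measured compounds named here, no pair of measured compounds shows this change, so its size cannot be read from the data. Since the rest of compound 1 is kept intact, the step of a 1.3-fold higher number from compound 1 to compound 4 (0.12 log units; within the scatter) is expected to be small, likely no further than the scatter and leaning toward a slightly higher number. Compound 4 is estimated at 160 nM, within 50 nM to 500 nM.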

Compound 4, half-maximal inhibitory concentration: 129 nM
The estimate for compound 4 lay 1.2-fold (0.09 log units) above the measured number, within the range that was stated.
By their numbers in this assay, from the lowest: compound 2; then compounds 1 and 4 (each within the scatter of the next); then compound 3.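

In this assay, for the compounds shown here, going from 1-isobutylpiperidin-4-yl to 1-methylpiperidin-4-yl gives a 1.1-fold higher number from compound 1 to compound 4 (0.03 log units; within the scatter), the first reading of this change. At this place on the amine, the 3 heavy atoms of the isopropyl can go without a step beyond the scatter. Nothing available here accounts for this result.

Still open, on these data alone, is whether a larger group such as benzyl, or an acetyl group, on that amine nitrogen in a ring would also stay within the scatter of compound 1.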